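The compounds below may be only part of what the source reports. "The series", "measured", "known", "first", "only" and "open" are said of these compounds alone.

Notes on the series. Compound 3 `Cc1ccc(S(=O)(=O)c2cnc3cc(F)ccc3c2N2CCC(C)CC2)cc1F` carries a 3-fluoro-4-methylphenyl on the sulfonyl sulfur, and in an assay on isolated protein for displacement of a labelled ligand from metabotropic glutamate receptor 5 (Homo sapiens), with a stated time of 60 min, tested at 1 uM (on this read-out lower numbers stand for less inhibition and higher numbers for more inhibition at the one concentration tested (going by the name of the read-out)), compound 3 gives 89%. Compound 1 `Cc1ccc(S(=O)(=O)c2cnc3cc(F)ccc3c2N2CCC(C)CC2)cc1Cl` has 3-chloro-4-methylphenyl in that place and gives 93%; compound 2 `CC1CCN(c2c(S(=O)(=O)c3cccc(C#N)c3)cnc3cc(F)ccc23)CC1` has 3-cyanophenyl there and gives 92%. The three readings sit within the scatter of one another: a number 4 percentage points lower from compound 1 to compound 3 (within the scatter), a number 3 percentage points lower from compound 2 to compound 3 (within the scatter), a number 1 percentage points lower from compound 1 to compound 2 (within the scatter). Compound 4 `Cc1ccc(S(=O)(=O)c2cnc3cc(F)ccc3c2N2CCC(C)CC2)cc1` is the unmeasured member. The change is hydrogen in place of fluoro on an aromatic carbon: the fluoro that stands ortho to a methyl group leaves and hydrogen enters, so the aryl on the sulfonyl sulfur reads 4-methylphenyl. The step that bears most directly on this is a number 4 percentage points lower from compound 1 to compound 3 (within the scatter), where one halogen replaced another on this aromatic carbon with no movement beyond the scatter; the whole-aryl swaps a number 1 percentage points lower from compound 1 to compound 2 (within the scatter) and a number 3 percentage points lower from compound 2 to compound 3 (within the scatter) also stayed within the scatter. No step beyond the scatter is expected here, and the expected step is a number 1 percentage points lower from compound 3 to compound 4 (within the scatter). Compound 4 is therefore estimated at 88%, with a range from 78% to 96%.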

Compound 4, a percentage reported as inhibition, at one concentration (the size of the read-out at that concentration, not a potency): 88%
Estimate against measurement, compound 4: no gap at the digits printed, and the stated range covers the measured number.
By their numbers in this assay, from the lowest: compounds 4, 3, 2 and 1 (each within the scatter of the next).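

Hydrogen on this aromatic carbon is now tested for the first time in this assay, and a number 1 percentage points lower from compound 3 to compound 4 (within the scatter) shows that, in this series, a halogen at this position is not required for the reading to stay within the scatter. The earlier compounds shown here only swapped one halogen for another or exchanged the whole aryl, whereas a number 5 percentage points lower from compound 1 to compound 4 (within the scatter) sets the unsubstituted position directly against chloro, and a number 4 percentage points lower from compound 2 to compound 4 (within the scatter) sets 4-methylphenyl against 3-cyanophenyl, with both steps remaining within the scatter. No supporting data are available to explain these readings.

Because each reading comes from one concentration, any potency differences among the four compounds remain unresolved. Also open, as far as these compounds go, is whether a methoxy, an amine or a carboxylic acid on this aromatic carbon would stay within the same scatter.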